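Swapping a Furan for an Ethyl in a Sulfamate Series

The compounds below may be only part of what the source reports. "The series", "measured", "known", "first", "only" and "open" are said of these compounds alone.

compound 1: `NS(=O)(=O)Oc1ccc2c(c1)CN(C(=O)c1ccc(N(Cc3ccccc3)Cc3ccco3)cc1)CC2` gives 90.8%
compound 2: `CN(C)CCCN(Cc1ccccc1)c1cccc(C(=O)N2CCc3ccc(OS(N)(=O)=O)cc3C2)c1` gives 23.8%
compound 3: `CC(C)CCN(CCC(C)C)c1cccc(C(=O)N2CCc3ccc(OS(N)(=O)=O)cc3C2)c1` gives 32.3%

In an assay on HEK293 cells for inhibition of Steryl-sulfatase (Homo sapiens), tested at 0.1 uM (a higher number here means a stronger effect of the compound at the concentration tested, a lower number a weaker effect), compound 1 stands highest of the three measured compounds; its lead over compound 3, the nearest, and over compound 2, the furthest, is in each case beyond the scatter. Compound 4 `CCCN(Cc1ccccc1)c1ccc(C(=O)N2CCc3ccc(OS(N)(=O)=O)cc3C2)cc1` has not yet been measured. It differs from compound 1 by ethyl in place of furan-2-yl on a saturated chain carbon bound to a nitrogen on an aromatic ring. Going by the values given here, no step between measured compounds is available that isolates this change, so the expectation rests on compound 1 alone. Losing the five-membered aromatic ring is expected to cost something, though the shared core and the benzyl remain, so a moderate downward step a number 16.8 percentage points lower from compound 1 to compound 4 (beyond the scatter) is expected rather than a collapse. Compound 4 is estimated to give 74%, within a range from 50% to 92%.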

Compound 4, a percentage reported as inhibition, at one concentration (the size of the read-out at that concentration, not a potency): 64.8%
Compound 4: middle estimate off by 9.2 percentage points, on the high side, and the stated range covers the measured number.
By their numbers in this assay, from the lowest: compounds 2 and 3 (each within the scatter of the next); then compound 4; then compound 1.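

In this assay, the first step isolating this place, ethyl in place of furan-2-yl on a saturated chain carbon bound to a nitrogen on an aromatic ring, gives a number 26 percentage points lower from compound 1 to compound 4 (beyond the scatter) and so shows that this position affects the read-out. Without the furan, compound 4 still gives 64.8% at the concentration tested, so the ring is not required for a clear effect. Nothing available accounts for the drop. The compounds shown leave open whether thiophen-2-yl or tetrahydrofuran-2-yl here would match compound 1, and whether the ring or its oxygen matters.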